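Carbamate Rearrangement on an Isoxazole Carboxylic Acid

This account rests on a few compounds, and the source may have more. Where it says the series, first, only, none or still open, it means among the compounds named here.

Compound 1, `Cc1cc(-c2nnn(C)c2COC(=O)N(C)CCC(C)C)ccc1O[C@H]1CCC[C@H](C(=O)O)C1`: 0.018
Compound 2, `Cc1noc(-c2ccc(O[C@H]3CCC[C@H](C(=O)O)C3)cc2)c1CNC(=O)OCCC(C)(C)C`: 0.004
Compound 3, `CN(C(=O)OCc1c(-c2ccc(O[C@H]3CCC[C@H](C(=O)O)C3)cc2)nnn1C)C1CCCC1`: 0.024

Of the compounds shown here, three have been measured in an ADME assay on the whole organism (plasma, Mus musculus, strain CD-1) for protein binding, read by LC-MS, with a stated time of 24 h; a higher number here means a larger unbound share of the compound, a lower number a smaller unbound share. Compound 2 stands lowest of the three: its nearest neighbour is compound 1, whose number is higher by a margin beyond the scatter, and compound 3 lies further still above it. Compound 2 is thus the compound with the smallest unbound share among those measured.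

Compound 4, `Cc1noc(-c2ccc(O[C@H]3CCC[C@H](C(=O)O)C3)cc2)c1COC(=O)N(C)CCC(C)C`, has not yet been measured in this assay. It differs from compound 2 in one place: a group of 10 heavy atoms (7 carbon, 1 nitrogen, 2 oxygen; no ring) in place of a group of 10 heavy atoms (7 carbon, 1 nitrogen, 2 oxygen; no ring), on a saturated chain carbon bound to an aromatic carbon. The entering group is the same one that compound 1 carries on its own, different core.

For the measured compounds named here, no pair of measured compounds differs in a single place, so no measured step guides this change directly. The expectation for compound 4 rests on compound 1, which gives 0.018 with the same entering group, and on compound 3 with its related group. On that basis the step of a 2.8-fold higher number from compound 2 to compound 4 (0.44 log units; beyond the scatter) is expected to be upward and beyond the scatter, though the change of core between compound 1 and compound 4 leaves the size uncertain. Compound 4 is therefore estimated at 0.011, within a range from 0.004 to 0.03.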

Compound 4, unbound fraction: 0.004
Estimate against measurement, compound 4: 2.8-fold (0.44 log units) above, and the stated range covers the measured number.
By their numbers in this assay, from the lowest: compounds 2 and 4 (each within the scatter of the next); then compounds 1 and 3 (each within the scatter of the next).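

For the compounds shown here, the first pair in this set to differ in one place shows, in this assay, no change at the digits printed from compound 2 to compound 4 (within the scatter) and so gives a direct reading of this position for the first time. The two compounds hold the same atoms, joined differently: a group with 1 hydrogen-bond donor leaves and a group with 0 hydrogen-bond donors enters, on a saturated chain carbon bound to an aromatic carbon, and on this shared core the unbound fraction stays within the scatter across that exchange. No measurement at hand explains why the unbound fraction stays in place across this exchange.

The compounds shown leave open whether a different kind of group at this place, such as an amine or a longer chain, would shift the unbound fraction on this core, since both groups compared here have the same atoms. Going by these compounds alone, they also leave open whether the same exchange would behave alike on the core of compound 1 or the core of compound 3, for which no pair differing in one place is at hand.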